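The source may hold more compounds than are shown below. What is called first, only, known or untested is meant among the compounds shown, and "the series" means these compounds.

Of the compounds shown here, two built on a shared core have so far been tested in a functional assay on HeLa cells (Homo sapiens) for cytotoxicity, read by MTT assay, with a stated time of 2 days, tested at 1 uM; on this read-out higher numbers stand for a weaker effect at the one concentration tested and lower numbers for a stronger effect. Compound 1, `CC(=O)c1cc(-c2ccc(F)cc2)cc2cc(-c3ccccc3)[nH]c12`, gives 82.7% in this assay. Compound 2, `COc1ccc(-c2cc3cc(-c4ccccc4)cc(C(C)=O)c3[nH]2)cc1`, gives 61.5% in this assay. For the measured compounds named here, of these two numbers compound 2 stands lowest, and its only neighbour, compound 1, lies higher by a margin beyond the usual scatter, so compound 2 shows the stronger effect of the pair at the single concentration tested.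

Compound 3, `COc1ccc(-c2cc3cc(-c4ccc(F)cc4)cc(C(C)=O)c3[nH]2)cc1`, has not yet been measured in this assay. It differs from compound 2 in one place: fluoro in place of hydrogen on an aromatic carbon. Going by the values given here, no pair of measured compounds differs by this same change alone, so the data give no direct reading of what it does. The change adds one heavy atom and no ring, and the step expected from it is a number 3.5 percentage points higher from compound 2 to compound 3 (within the scatter), small and possibly not beyond the scatter, with no clear direction. For compound 3 the estimated value in this assay is 65%, with a range from 45% to 85%.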

Compound 3, a percentage reported as activity, at one concentration (the size of the read-out at that concentration, not a potency): 62.9%
Compound 3: middle estimate off by 2.1 percentage points, on the high side, and the stated range covers the measured number.
By their numbers in this assay, from the lowest: compounds 2 and 3 (each within the scatter of the next); then compound 1.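

In this assay, the swap of hydrogen for fluoro, which turns a phenyl into a 4-fluorophenyl para to a large group, gives a number 1.4 percentage points higher from compound 2 to compound 3 (within the scatter), so with a methoxy group present, compound 2 and compound 3 cannot be told apart at this one concentration. For the compounds shown here, the second pair, whose only difference is the presence of the methoxy group, gives a number 19.8 percentage points lower from compound 1 to compound 3 (beyond the scatter), the first single-place step beyond the scatter, and so ties the stronger effect seen here to the methoxy group in the presence of fluoro, though this rests on one pair alone. Nothing available explains why either step has the size it has.

The compounds shown leave open whether another group at the fluoro position, such as chloro, an amine or a carboxylic acid, would shift the read-out beyond the scatter. They also leave open whether fluoro would read the same without the methoxy group, and whether a longer chain in place of that methoxy would keep the stronger effect.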